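This account rests on a few compounds, and the source may have more. Where it says the series, first, only, none or still open, it means among the compounds named here.

Measured so far in a functional assay on SF-539 cells (Homo sapiens) for inhibition, read by sulforhodamine B assay, with a stated time of 48 h, tested at 100 uM; a lower number here means a stronger effect, a higher number a weaker effect of the compound at the concentration tested:

compound 1, `COc1cc(Cl)cc(-c2nn(-c3cccc(NC(=O)Nc4ccc(Cl)c(C(F)(F)F)c4)c3)cc2-c2ccncc2)c1`, gives -78%
compound 2, `COc1cc(Cl)cc(-c2nn(-c3cccc(NC(=O)Nc4cc(C(F)(F)F)cc(C(F)(F)F)c4)c3)cc2-c2ccncc2)c1`, gives -73%
compound 3, `COc1cc(Cl)cc(-c2nn(-c3cccc(NC(=O)Nc4ccc(Cl)c(Cl)c4)c3)cc2-c2ccncc2)c1`, gives -40%

On these numbers compound 3 stands highest of the three: its nearest neighbour is compound 2, whose number is lower beyond the scatter, and its furthest is compound 1, lower again beyond the scatter. Among the measured compounds shown here, the single measured step that touches compound 3 is a number 38 percentage points higher from compound 1 to compound 3 (beyond the scatter), a large rise in the number when chloro replaced trifluoromethyl on an aromatic carbon.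

Compound 4, `COc1cc(Cl)cc(-c2nn(-c3cccc(NC(=O)Nc4cccc(C(F)(F)F)c4)c3)cc2-c2ccncc2)c1`, has not yet been measured. It differs from compound 3 by 3-(trifluoromethyl)phenyl in place of 3,4-dichlorophenyl on an amide-type nitrogen. This change brings back a trifluoromethyl group of the kind that compound 1 and compound 2 carry, both of which give low numbers, while the second chloro is not replaced. For the measured compounds named here, since the only measured step, a number 38 percentage points higher from compound 1 to compound 3 (beyond the scatter), shows the number rising with the loss of trifluoromethyl, the return of trifluoromethyl in compound 4 is expected to move the number down beyond the scatter, a step of a number 20 percentage points lower from compound 3 to compound 4 (beyond the scatter). The estimate for compound 4 in this assay is therefore -60%, with a range from -85% to -30%.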

Compound 4, a percentage reported as activity, at one concentration (the size of the read-out at that concentration, not a potency): -72%
Compound 4: middle estimate off by 12 percentage points, on the high side; the range from low to high includes it.
By their numbers in this assay, from the lowest: compounds 1, 2 and 4 (each within the scatter of the next); then compound 3.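

On the aryl group at the amide-type nitrogen, the large step of a number 32 percentage points lower from compound 3 to compound 4 (beyond the scatter) shows that 3-(trifluoromethyl)phenyl alone reaches the low numbers of the earlier trifluoromethyl compounds, even though it carries one substituent fewer than 3,4-dichlorophenyl. Adding a second group to that ring shows no measurable gain, neither the second trifluoromethyl, a number 1 percentage points higher from compound 2 to compound 4 (within the scatter), nor the chloro, a number 6 percentage points higher from compound 1 to compound 4 (within the scatter), so among these four compounds the three with a trifluoromethyl group lie together and compound 3, which has none, stands apart. Nothing among the data shown accounts for this difference.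

Going by these compounds, it remains open whether a lone chloro, with no second chloro on the ring, would behave like trifluoromethyl or like the 3,4-dichlorophenyl group. The compounds shown also leave open how a nitrile or a primary amine at that ring would read in this assay.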